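Swapping the aryl group on a well-tolerated compound

The compounds below may be only part of what the source reports. "The series", "measured", "known", "first", "only" and "open" are said of these compounds alone.

In an ADME assay on MDBK cells (Bos taurus) for cytotoxicity, read by MTT assay, with a stated time of 96 h (a lower number here means that less compound is tolerated, a higher number that more compound is tolerated), compound 3 `C/C(=N\NC(N)=O)c1ccc2c(c1)nc(-c1ccc(C(F)(F)F)cc1)n2C1CCCCC1` gives > 100000 nM, which is a limit and not a number. Compound 1 `C/C(=N\NC(N)=O)c1ccc2[nH]c(-c3ccc(C(F)(F)F)cc3)nc2c1` gives > 100000 nM, also a limit. Compound 2 `C/C(=N\NC(N)=O)c1ccc2c(c1)nc(-c1ccc(Cl)cc1)n2C1CCCCC1` gives > 100000 nM, again a limit.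

The next structure, compound 4 `C/C(=N\NC(N)=O)c1ccc2c(c1)nc(-c1ccoc1)n2C1CCCCC1`, carries furan-3-yl in place of 4-(trifluoromethyl)phenyl on an aromatic carbon. The nearest measured changes are a step that the two limits leave unreadable from compound 1 to compound 3 and a step that the two limits leave unreadable from compound 2 to compound 3, so neither offers a size to carry over. The expectation therefore rests only on (the limit of > 100000 nM in this assay, at which 3 of the 3 values shown sit).

No step beyond the scatter is expected in this assay, and the estimated change is a number no higher from compound 3 to compound 4 (the limit leaves the size open). For compound 4, the expected value is 100000 nM, within an estimated range of 40000 nM to 100000 nM.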

Compound 4, half-maximal cytotoxic concentration: > 100000 nM
Compound 4 was reported as a limit (the forecaster's own chance of this, stated with the estimate: 80%); the middle value lies on the limit itself.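

Compound 4 is again reported only as a limit, so no step can be read from compound 2 or compound 3 to compound 4: the limit of > 100000 nM in this assay, at which 4 of the 4 values shown sit.

From the compounds shown here alone, whether furan-3-yl, 4-chlorophenyl and 4-(trifluoromethyl)phenyl differ at all in the concentration tolerated remains open.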